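The source may report more compounds than this note shows. Statements on the series, on what has been measured and on what is new or still open speak of the compounds shown alone.

Three compounds have been measured in an assay for antagonist activity at P2X purinoceptor 7 (Homo sapiens), read by ELISA, with a stated time of 30 min; a lower number here means a stronger inhibitor, a higher number a weaker inhibitor:

compound 1, `COCCNc1ccc2c(C(=O)NCC3CCC(F)(F)CC3)c(Cl)ccc2n1`, 180 nM
compound 2, `O=C(NCC1CCC(F)(F)CC1)c1c(Cl)ccc2ncccc12`, 220 nM
compound 3, `O=C(NCC1CCC(F)(F)CC1)c1c(Cl)ccc2nc(C3=CCCC3)ccc12`, 90 nM

Compound 3 holds the lowest of the three numbers. Its nearest neighbour is compound 1, and the step of a 2.0-fold lower number from compound 1 to compound 3 (0.30 log units; within the scatter) stays within the scatter, whereas a 2.4-fold lower number from compound 2 to compound 3 (0.39 log units; beyond the scatter) lies beyond it. Compound 4, `O=C(NCC1CCC(F)(F)CC1)c1c(Cl)ccc2nc(NCCO)ccc12`, differs from compound 3 in one place: (2-hydroxyethyl)amino in place of cyclopent-1-en-1-yl on an aromatic carbon. Among the measured compounds shown here, two measured steps bear on this change. The step of a 2.4-fold lower number from compound 2 to compound 3 (0.39 log units; beyond the scatter) shows what the cyclopent-1-en-1-yl group gives over hydrogen, and the step of a 2.0-fold lower number from compound 1 to compound 3 (0.30 log units; within the scatter) shows how the same group compares with a (2-methoxyethyl)amino group at that position. The (2-hydroxyethyl)amino group of compound 4 is closer in kind to the group of compound 1 than to a bare hydrogen, so taking away the cyclopent-1-en-1-yl group is expected to return most of what those two steps gained. Compound 4 is therefore expected to show a step of a 2.0-fold higher number from compound 3 to compound 4 (0.30 log units; within the scatter) in this assay. That expectation leans on compound 1, whose value of 180 nM marks where a chain of this kind stood. The estimate for compound 4 in this assay is 180 nM, with a range from 80 nM to 400 nM.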

Compound 4, half-maximal inhibitory concentration: 76 nM
For compound 4 the middle estimate is 2.4-fold (0.37 log units) above the measured one, outside the stated range (below it).
By their numbers in this assay, from the lowest: compounds 4, 3, 1 and 2 (each within the scatter of the next, the first and the last beyond it).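

In this assay, this aromatic carbon next to the ring nitrogen accepts two very different groups without a clear change, a 1.2-fold lower number from compound 3 to compound 4 (0.07 log units; within the scatter), so the ring of carbon and the double bond of cyclopent-1-en-1-yl are not needed to hold the number reached by compound 3, and a chain with no ring and with hydrogen-bond donors and acceptors serves as well. The earlier compounds shown here left the value of an amino chain here unclear, as its step from hydrogen stayed within the scatter (a 1.2-fold higher number from compound 1 to compound 2 (0.09 log units; within the scatter)), but the hydroxy chain clears that scatter, a 2.9-fold lower number from compound 2 to compound 4 (0.46 log units; beyond the scatter), and the exchange of a single methyl for hydrogen on the chain oxygen is itself a step beyond the scatter, a 2.4-fold lower number from compound 1 to compound 4 (0.37 log units; beyond the scatter). Nothing measured here accounts for these steps.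

The compounds shown leave open whether a longer chain, such as (3-hydroxypropyl)amino, would keep this number, or whether a primary amine or a carboxylic acid could stand in place of the hydroxyl. They also leave open what happens if an ether oxygen replaces the chain's amino nitrogen, as in 2-hydroxyethoxy.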